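From 2,4-Dimethylphenyl to 3,5-Difluorophenyl on a Ring Nitrogen

The compounds below may be only part of what the source reports. "The series", "measured", "known", "first", "only" and "open" are said of these compounds alone.

In a functional assay on PC-12 cells (Rattus norvegicus) for cytotoxicity, read by MTT assay, with stated times of 2 h and 24 h, tested at 1 uM (a lower number here means a weaker effect, a higher number a stronger effect of the compound at the concentration tested), compound 1 `Oc1cc(C(F)(F)F)ccc1-c1nc(-c2ccccc2O)n(-c2cccc(Cl)c2)n1` gives 72.3%, and compound 2 `Cc1ccc(-n2nc(-c3ccc(C(F)(F)F)cc3O)nc2-c2ccccc2O)c(C)c1` gives 73.7%. Among the measured compounds shown here, compound 2 thus cannot be told apart from the only other number, since a number 1.4 percentage points higher from compound 1 to compound 2 (within the scatter). Compound 3 `Oc1cc(C(F)(F)F)ccc1-c1nc(-c2ccccc2O)n(-c2cc(F)cc(F)c2)n1` differs by 3,5-difluorophenyl in place of 2,4-dimethylphenyl on an aromatic nitrogen. For the measured compounds named here, the single measured step, from compound 1 to compound 2, also exchanged the group on that aromatic nitrogen and stayed within the scatter, so no change beyond the scatter is expected here either. Compound 3 is therefore estimated to give 72%, between 60% and 84%. The expected step is a number 1.7 percentage points lower from compound 2 to compound 3 (within the scatter).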

Compound 3, a percentage reported as activity, at one concentration (the size of the read-out at that concentration, not a potency): 75.5%
Estimate against measurement, compound 3: 3.5 percentage points below; the measured number falls inside the stated range.
By their numbers in this assay, from the lowest: compounds 1, 2 and 3 (each within the scatter of the next).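

Swapping two methyl groups for two fluorines on the phenyl ring at this aromatic nitrogen leaves the reading in this assay within the scatter (a number 1.8 percentage points higher from compound 2 to compound 3 (within the scatter)). The 3,5-difluorophenyl group also cannot be told apart from 3-chlorophenyl (a number 3.2 percentage points higher from compound 1 to compound 3 (within the scatter)), so this position has now tolerated halogen and methyl substituents alike, in differing ring positions. No measurement shown here explains this flat result. Still open, on these data alone, is whether something other than a substituted phenyl at this nitrogen, such as a longer alkyl chain, or a phenyl carrying an amine or a carboxylic acid, would move the number beyond the scatter.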